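A few compounds are considered here, and "the series" means these few. Any claim that something is new, unique, unknown or untested is made for them only; others in the source may bear on it.

Three compounds share one core and differ only in the aryl group attached to the amide carbonyl. Compound 1 `O=C(Nc1cccc(-c2oc3cc(-c4ccc(F)cc4)ccc3c(=O)c2O)c1)c1ccc(Cl)cc1` gives 10800 nM in a functional assay on A549 cells (Homo sapiens) for antiproliferative activity, read by CCK-8 assay, with a stated time of 72 h; a lower number here means a stronger inhibitor, a higher number a weaker inhibitor. Compound 2 `COc1ccccc1C(=O)Nc1cccc(-c2oc3cc(-c4ccc(F)cc4)ccc3c(=O)c2O)c1` gives 11700 nM. Compound 3 `O=C(Nc1cccc(-c2oc3cc(-c4ccc(F)cc4)ccc3c(=O)c2O)c1)c1ccc(Br)cc1` gives 13500 nM. Among these three numbers, compound 2 stands nearest to compound 1 and furthest from compound 3, yet both gaps are within the scatter, so the three compounds cannot be told apart on this assay.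

Compound 4 `O=C(Nc1cccc(-c2oc3cc(-c4ccc(F)cc4)ccc3c(=O)c2O)c1)c1cccc(F)c1` is not yet measured. It differs from compound 2 in one place: 3-fluorophenyl in place of 2-methoxyphenyl on a carbonyl carbon.

Going by the values given here, two measured steps bear on this, since each swaps the aryl group on the same carbonyl carbon: a 1.1-fold higher number from compound 1 to compound 2 (0.03 log units; within the scatter) and a 1.2-fold higher number from compound 2 to compound 3 (0.06 log units; within the scatter). Neither swap moved the number beyond the scatter, and the swap from chloro to bromo, a 1.3-fold higher number from compound 1 to compound 3 (0.10 log units; within the scatter), did not either. A further swap of this aryl group is therefore expected to leave the number where it is, within the scatter, in either direction. Compound 4 is expected to give about 11500 nM, in a range from 6000 nM to 22000 nM, which corresponds to an expected step of a 1.0-fold lower number from compound 2 to compound 4 (0.01 log units; within the scatter).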

Compound 4, half-maximal inhibitory concentration: 15400 nM
Compound 4: middle estimate off by 1.3-fold (0.13 log units), on the low side; low and high end bracket the measured number.
By their numbers in this assay, from the lowest: compounds 1, 2, 3 and 4 (each within the scatter of the next).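

In this assay, putting 3-fluorophenyl, which has no hydrogen-bond acceptor, in place of 2-methoxyphenyl, which has one, gives a 1.3-fold higher number from compound 2 to compound 4 (0.12 log units; within the scatter), so this change in acceptor count on the carbonyl carbon produces no step beyond the scatter. The comparisons with the two halogen-bearing groups agree, with a 1.1-fold higher number from compound 3 to compound 4 (0.06 log units; within the scatter) and a 1.4-fold higher number from compound 1 to compound 4 (0.15 log units; within the scatter), and even this last, the largest step among the four compounds, leaves them indistinguishable. Nothing available explains why these four aryl groups read alike.

From the compounds shown here alone, all four groups are substituted phenyl rings, so it remains open whether a longer alkyl chain on this carbonyl carbon, or a phenyl ring carrying an amine or a carboxylic acid, would move the number beyond the scatter. Going by these compounds, the rest of the molecule stays the same throughout, so the effect of replacing the 4-fluorophenyl on the shared core also remains open.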